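Working notes: aryl swap from compound 2 to compound 3

The source may report more compounds than this note shows. Statements on the series, on what has been measured and on what is new or still open speak of the compounds shown alone.

The series is read in a functional assay on HeLa cells (Homo sapiens) for antiproliferative activity, read by MTT assay, with a stated time of 72 h; a lower number here means a stronger inhibitor, a higher number a weaker inhibitor. Among the compounds with values here, compound 1 `O=c1nc2oc(CCCCl)c(C#CCCCCl)c2cn1Cc1cn(-c2ccc(Cl)cc2)nn1` reaches only a limit of the assay, > 100000 nM, and it is the one value sitting at the limit of > 100000 nM in this assay, at which 1 of the 2 values shown sits. Within the data shown here, compound 2 `O=c1nc2oc(CCCCl)cc2cn1Cc1cn(-c2ccc(Cl)cc2)nn1` gives 60200 nM, the only measured number so far. Among the measured compounds shown here, the single step on record, an at least 1.6-fold lower number from compound 1 to compound 2 (0.22 log units; that floor lies within the scatter), removes a side chain from an aromatic carbon of the shared core and leaves the number close to its starting point in size.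

Compound 3 `O=c1nc2oc(CCCCl)cc2cn1Cc1cn(-c2ccccc2F)nn1` changes a different place: 2-fluorophenyl in place of 4-chlorophenyl on an aromatic nitrogen. For the measured compounds named here, no measured step touches the aromatic nitrogen that carries this group, so the one recorded step offers no direct guide to this change. With nothing comparable on record, the step of a 1.0-fold lower number from compound 2 to compound 3 (0.00 log units; within the scatter) is expected to stay within the scatter, in no particular direction. Compound 3 is therefore estimated at 60000 nM, with a range from 20000 nM to 150000 nM.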

Compound 3, half-maximal inhibitory concentration: 66500 nM
Estimate against measurement, compound 3: 1.1-fold (0.04 log units) below, within the range that was stated.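

Within the data shown here, this is the first reading at the aromatic nitrogen of the five-membered ring, and in this assay the exchange of 4-chlorophenyl for 2-fluorophenyl gives no step that can be told from noise: a 1.1-fold higher number from compound 2 to compound 3 (0.04 log units; within the scatter). Among these compounds, the exchange alters the halogen and its place on the phenyl ring together, and this single pair cannot separate the two, so it shows only that this combined swap leaves compound 2 and compound 3 indistinguishable in this read-out. Neither aryl group brings the number out of the high range of the series, where the ceiling of the assay lies close and one compound already stands at a limit: the limit of > 100000 nM in this assay, at which 1 of the 3 values shown sits.

Still open, from the compounds shown here alone, is whether this nitrogen accepts groups other than a halogen-bearing phenyl, such as an unsubstituted phenyl, a phenyl carrying an amine or a carboxylic acid, or a benzyl group. Also open, going by these compounds, is whether any stronger number lies in the chain shared by compound 2 and compound 3, for instance with a hydroxyl or an amine in place of its terminal chlorine, or with a longer chain.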